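This account rests on a few compounds, and the source may have more. Where it says the series, first, only, none or still open, it means among the compounds named here.

Three compounds have been measured so far in a functional assay on NRK-49F cells (Rattus norvegicus) for cytotoxicity, read by MTT assay, with a stated time of 24 h (on this read-out higher numbers stand for weaker inhibition and lower numbers for stronger inhibition), with these values:

Compound 1 (`COc1ccc(/C=C(\C#N)C(=O)N/N=C(\C)c2c(O)c3ccc(O)cc3oc2=O)cc1`) 96100 nM
Compound 2 (`COc1cc(/C=C(\C#N)C(=O)N/N=C(\C)c2c(O)c3ccc(O)cc3oc2=O)cc(OC)c1OC`) 55300 nM
Compound 3 (`C/C(=N\NC(=O)/C(C#N)=C/c1ccc(Br)cc1)c1c(O)c2ccc(O)cc2oc1=O`) 49600 nM

Compound 1 does not separate from the other two on these numbers. Its value lies within the scatter of both compound 2 and compound 3, so the three read as a single group.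

Compound 4 (`C/C(=N\NC(=O)/C(C#N)=C/c1ccccc1Cl)c1c(O)c2ccc(O)cc2oc1=O`) has not yet been measured. It differs from compound 1 by 2-chlorophenyl in place of 4-methoxyphenyl on a double-bonded chain carbon bound to a double-bonded chain carbon. Within the data shown here, one measured step bears on this change, a 1.9-fold lower number from compound 1 to compound 3 (0.29 log units; within the scatter) for bromo in place of methoxy on an aromatic carbon, and it stays within the scatter. Among the measured compounds shown here, no measured compound carries the 2-chlorophenyl group, so this guide is only partial.

With compound 3 at 49600 nM as the closest guide, no step beyond the scatter is expected in this assay from this change, though a somewhat lower number is the likelier direction. The expected step is a 1.6-fold lower number from compound 1 to compound 4 (0.20 log units; within the scatter) and should remain within the scatter. For compound 4 the estimated value is 60000 nM with an expected range from 30000 nM to 110000 nM on this estimate.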

Compound 4, half-maximal inhibitory concentration: 55900 nM
For compound 4 the middle estimate is 1.1-fold (0.03 log units) above the measured one, and the stated range covers the measured number.
By their numbers in this assay, from the lowest: compounds 3, 2, 4 and 1 (each within the scatter of the next).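

In this assay, 2-chlorophenyl in place of 4-methoxyphenyl on a double-bonded chain carbon bound to a double-bonded chain carbon gives a 1.7-fold lower number from compound 1 to compound 4 (0.24 log units; within the scatter), so a second group at this place, and the first bearing chlorine, also stays within the usual spread of the measurement. Among these compounds, the comparison between the two halogen-bearing groups, which the earlier compounds could not offer, gives a 1.1-fold higher number from compound 3 to compound 4 (0.05 log units; within the scatter), so 2-chlorophenyl and 4-bromophenyl cannot be told apart here, and neither the choice of halogen nor its place on the ring, which change together in this pair, shows any separate effect on the read-out. No measurement is available that would account for this flat picture.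

From the compounds shown here alone, all four compounds carry a substituted phenyl ring at this place, so it remains open whether an amine or a carboxylic acid on that ring, or a longer chain in place of the ring, would give a step beyond the scatter. The compounds shown also leave open what a change elsewhere on the shared core would do, such as replacing the methyl group on the chain with an ethyl group.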